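Two spiroperoxide pairs and a single aromatic substitution

The source may hold more compounds than are shown below. What is called first, only, known or untested is meant among the compounds shown, and "the series" means these compounds.

The study concerns three measured compounds and a fourth not yet tested. In a functional assay on BEAS-2B cells (Homo sapiens) for inhibition, read by MTT assay, with a stated time of 72 h (a higher number here means a weaker inhibitor, a lower number a stronger inhibitor), compound 1 `C=C(c1ccc(OC)c(F)c1)C1COC2(CCCC2)OO1` gives 55800 nM. Compound 2 `C=C(c1ccc(F)c(F)c1)C1COC2(CCCC2)OO1` gives 73600 nM in this assay. Compound 3 `C=C(c1ccc(F)c(F)c1)C1COC2(CCCCC2)OO1` gives 61200 nM in this assay. Compound 4 `C=C(c1ccc(OC)c(F)c1)C1COC2(CCCCC2)OO1` has not yet been measured in this assay.

Compound 1 and compound 2 share a core and differ at one place: methoxy in place of fluoro on an aromatic carbon. The step of a 1.3-fold lower number from compound 2 to compound 1 (0.12 log units; within the scatter) shows that this substitution left the number essentially where it was. Compound 3 and compound 2 carry the same aromatic substitution pattern; the difference between their two cores is not broken down here, and their two values lie close together.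

Compound 4 stands to compound 3 exactly as compound 1 stands to compound 2: methoxy in place of fluoro on an aromatic carbon. The place lines of the two substitutions match word for word. This is the same change made on the core of compound 3. The expectation rests on compound 2 and compound 1, whose step a 1.3-fold lower number from compound 2 to compound 1 (0.12 log units; within the scatter) stayed within the scatter. The step from compound 3 to compound 4 is therefore expected to be small, about a 1.3-fold lower number from compound 3 to compound 4 (0.11 log units; within the scatter). On that basis compound 4 is estimated to give 48000 nM in this assay, with a plausible range from 25000 nM to 92000 nM.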

Compound 4, half-maximal inhibitory concentration: 37700 nM
For compound 4 the middle estimate is 1.3-fold (0.10 log units) above the measured one; measured number inside the range.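

In this assay, putting methoxy in place of fluoro on an aromatic carbon of the core of compound 3 gave a 1.6-fold lower number from compound 3 to compound 4 (0.21 log units; within the scatter), so the change again left the number within the usual variation between repeats. Set beside the earlier case, the change carries from one core to the other with no difference that can be told apart from scatter: the same change on two cores in this assay, a 1.3-fold lower number (0.12 log units; within the scatter) from compound 2 to compound 1 and a 1.6-fold lower number (0.21 log units; within the scatter) from compound 3 to compound 4, 1.2-fold (0.09 log units) apart, within the scatter of two such steps What this does not show is that methoxy and fluoro truly differ in this assay, since neither step alone stands clear of the scatter, nor does agreement on two closely related cores establish that the change would behave the same way on any further core.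

The compounds shown leave open what other groups would do at this place on the aromatic ring, for example an amine, a carboxylic acid or a longer chain such as ethoxy, none of which appears among them. They also leave open whether the small size of this step would persist on a core other than those of compound 1 and compound 3, or on cells other than those tested here.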